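The source may hold more compounds than are shown below. What is called first, only, known or untested is meant among the compounds shown, and "the series" means these compounds.

Measured compounds:
compound 1, `N=C(N)c1ccc(-c2ccc(-c3cc(Cl)cc(Cl)c3)s2)s1` — 2240 nM
compound 2, `COc1ccc(-c2ccc(-c3ccc(C(=N)N)o3)o2)cc1` — 5710 nM

Both were tested in a functional assay on SK-MEL-2 cells (Homo sapiens) for inhibition, read by sulforhodamine B assay, with a stated time of 48 h; on this read-out higher numbers stand for weaker inhibition of growth and lower numbers for stronger inhibition of growth. Of the two numbers recorded, compound 2 gives the higher one, and the gap down to compound 1 lies beyond the usual scatter, so compound 2 is the weaker growth inhibitor of the pair on the numbers shown. For the measured compounds named here, compound 2 carries a methoxy group on its outer six-membered aromatic ring of carbon only, para to a large group; compound 1 instead carries two chloro groups on a different core, so the two are not a single-change pair and no step between them can be counted.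

The next compound, compound 3, `N=C(N)c1ccc(-c2ccc(-c3ccc(Cl)cc3)o2)o1`, keeps the core of compound 2 and differs in one place: chloro in place of methoxy on an aromatic carbon. Going by the values given here, no measured pair in this set isolates a chloro for methoxy exchange, so the expectation rests only on the two values above. This estimate means an expected step of a 1.6-fold lower number from compound 2 to compound 3 (0.21 log units; within the scatter), towards stronger inhibition but no larger than the usual scatter. Compound 3 is expected to give about 3500 nM in this assay, within a range of 1200 nM to 10000 nM.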

Compound 3, concentration for 50% growth inhibition: 2080 nM
Compound 3: middle estimate off by 1.7-fold (0.23 log units), on the high side; low and high end bracket the measured number.
By their numbers in this assay, from the lowest: compounds 3 and 1 (each within the scatter of the next); then compound 2.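

On the six-membered aromatic ring of carbon only, para to a large group, chloro in place of methoxy gives a 2.7-fold lower number from compound 2 to compound 3 (0.44 log units; beyond the scatter) in this assay, a move towards stronger inhibition of growth. This is the only single-change pair among the compounds shown, and so the first direct reading of this position: it responds to the exchange, and of these two groups, chloro goes with the stronger inhibition. No measured evidence bears on what lies behind this step.

One exchange cannot separate the effect of removing methoxy from that of adding chloro, and a plain hydrogen, fluoro or trifluoromethyl on the same carbon would be needed to tell these apart. The compounds shown also leave open how an amine or a carboxylic acid at this position would read in this assay, and whether the same exchange would give a step of similar size on the core of compound 1.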